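Acetylated sugar enones: cytotoxicity notes on a dichlorophenyl analogue

The source may report more compounds than this note shows. Statements on the series, on what has been measured and on what is new or still open speak of the compounds shown alone.

The series shares a peracetylated sugar core carrying an enone chain that ends in an aryl ring. Compound 1 `CC(=O)OC[C@H]1O[C@@H](CC(=O)/C=C/c2cccnc2)[C@H](OC(C)=O)[C@@H](OC(C)=O)[C@@H]1OC(C)=O` carries a pyridinyl ring; in an ADME assay on cells (Epithelial cell, Homo sapiens) for cytotoxicity, read by MTT assay, with a stated time of 24 h (a higher number here means that more compound is tolerated, a lower number that less compound is tolerated), compound 1 gives 4.17 nM. In this assay, within the data shown here, compound 2 `CC(=O)OC[C@H]1O[C@@H](CC(=O)/C=C/c2ccc(N(C)C)cc2)[C@H](OC(C)=O)[C@@H](OC(C)=O)[C@@H]1OC(C)=O` gives "not determined" (no result reported) and compound 3 `CC(=O)OC[C@H]1O[C@@H](CC(=O)/C=C/c2ccc(OCc3ccccc3)cc2)[C@H](OC(C)=O)[C@@H](OC(C)=O)[C@@H]1OC(C)=O` gives "not determined" (no result reported); compound 2 therefore stands nowhere on the measured scale, and no step from it can be sized. Compound 4 `CC(=O)OC[C@H]1O[C@@H](CC(=O)/C=C/c2ccc(Cl)c(Cl)c2)[C@H](OC(C)=O)[C@@H](OC(C)=O)[C@@H]1OC(C)=O` is the unmeasured member; the change from compound 2 is 3,4-dichlorophenyl in place of 4-(dimethylamino)phenyl on a double-bonded chain carbon bound to a double-bonded chain carbon. With no value for compound 2, the expectation for compound 4 rests only on compound 1 and its reading in this assay, so no step size or direction is assigned. Compound 4 is expected to give 5 nM in this assay, within 1 nM to 40 nM.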

Compound 4, half-maximal cytotoxic concentration: 25.8 nM
For compound 4 the middle estimate is 5.2-fold (0.71 log units) below the measured one; the range from low to high includes it.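

In this assay, among these compounds, 3,4-dichlorophenyl in place of pyridin-3-yl on a double-bonded chain carbon bound to a double-bonded chain carbon gives a 6.2-fold higher number from compound 1 to compound 4 (0.79 log units; beyond the scatter) and provides the first sized change at this position. Steps involving compound 2 or compound 3 cannot be read. Nothing available explains this shift.

From the compounds shown here alone, whether the step follows the two chlorines or the loss of the pyridine nitrogen remains open. A phenyl ring bearing one chlorine, or a carboxylic acid on the ring, would test how far this position tolerates change.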